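The compounds below may be only part of what the source reports. "The series", "measured", "known", "first", "only" and "open" are said of these compounds alone.

Compound 1 `COc1ccc(/C=C2\CCC/C(=C\c3ccc(Br)cc3)C2=O)cc1` and compound 2 `COc1ccc(/C=C2\CCC/C(=C\c3ccc(F)cc3)C2=O)cc1` share one core; compound 3 `COc1cccc(/C=C2\CCC/C(=C\c3ccc(Br)cc3)C2=O)c1OC` and compound 4 `COc1cccc(/C=C2\CCC/C(=C\c3ccc(F)cc3)C2=O)c1OC` share another. How the two cores differ is not broken down here. In an ADME assay on Vero cells (Chlorocebus sabaeus) for inhibition (a lower number here means that less compound is tolerated, a higher number that more compound is tolerated), compound 1 gives 250000 nM and compound 2 gives 378000 nM; the change fluoro in place of bromo on an aromatic carbon makes a step of a 1.5-fold higher number from compound 1 to compound 2 (0.18 log units; within the scatter). In this assay compound 3 gives 31500 nM, the lowest number of the three, with compound 1 nearest and compound 2 furthest, both beyond the scatter. The change fluoro in place of bromo on an aromatic carbon is the same change as that from compound 1 to compound 2, at the same place, and has occurred once so far in this set. For compound 4 a step of a 1.4-fold higher number from compound 3 to compound 4 (0.15 log units; within the scatter) is expected in this assay because the same change gave a 1.5-fold higher number from compound 1 to compound 2 (0.18 log units; within the scatter). Compound 4 is therefore estimated at 45000 nM, expected to lie between 18000 nM and 110000 nM.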

Compound 4, half-maximal cytotoxic concentration: 33200 nM
Compound 4: the middle estimate sits 1.4-fold (0.13 log units) above what was measured; measured number inside the range.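

In this assay, fluoro in place of bromo on the core of compound 3 gives a 1.1-fold higher number from compound 3 to compound 4 (0.02 log units; within the scatter), so the 4-bromophenyl to 4-fluorophenyl change leaves no readable difference on this core. The two cores agree on this change: the same change on two cores in this assay, a 1.5-fold higher number (0.18 log units; within the scatter) from compound 1 to compound 2 and a 1.1-fold higher number (0.02 log units; within the scatter) from compound 3 to compound 4, 1.4-fold (0.16 log units) apart, within the scatter of two such steps. Among the compounds shown here, this shows that the step stays within the scatter on both cores, but with only two pairs and neither step beyond the scatter, it does not show that a sizeable effect would carry from one core to another, or that a third core would behave alike.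

Open, from the compounds shown here alone, is whether an amine, a carboxylic acid or a nitrile in place of the halogen would give a step beyond the scatter. Also open, going by these compounds, is whether such a step would carry between these two cores.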